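This account rests on a few compounds, and the source may have more. Where it says the series, first, only, none or still open, it means among the compounds named here.

Going by the values given here, in a functional assay on A549 cells (Homo sapiens) for inhibition, read by MTT assay, with a stated time of 72 h (a higher number here means a weaker inhibitor, a lower number a stronger inhibitor), compound 2 `Nc1nc2cc(-c3nn(CC(=O)NO)c4ncnc(N)c34)ccc2o1` gives 27700 nM, the only exact number so far. Compound 1 `Nc1nc2cc(-c3nn(CCCC(=O)NO)c4ncnc(N)c34)ccc2o1` reports only a limit, > 100000 nM. Compound 3 `Nc1nc2cc(-c3nn(CCCCCCC(=O)NO)c4ncnc(N)c34)ccc2o1` carries 5-(hydroxycarbamoyl)pentyl in place of hydroxycarbamoyl on a saturated chain carbon bound to an aromatic nitrogen, that is, 5-(hydroxycarbamoyl)pentyl in place of hydroxycarbamoyl on a saturated chain carbon bound to an aromatic nitrogen. Among the compounds with values here, the one measured step at this place, an at least 3.6-fold lower number from compound 1 to compound 2 (0.55 log units; beyond the scatter), favours the shorter chain, but it rests on a limit, and the chain of compound 3 is longer than that of compound 1. Going by these compounds, no step beyond the scatter is therefore expected in this assay, and the direction stays open; the expected step is a 1.4-fold lower number from compound 2 to compound 3 (0.14 log units; within the scatter). For compound 3 the estimated value is 20000 nM, with an expected range of 2000 nM to 100000 nM.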

Compound 3, half-maximal inhibitory concentration: 33000 nM
The estimate for compound 3 lay 1.7-fold (0.22 log units) below the measured number, and the stated range covers the measured number.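

In this assay, the long chain at this place costs nothing measurable against the shortest one: a 1.2-fold higher number from compound 2 to compound 3 (0.08 log units; within the scatter). Chain length therefore does not act as a steady trend here, since the intermediate chain gives the weak end of the series, with an at least 3.0-fold lower number from compound 1 to compound 3 (0.48 log units; beyond the scatter). That contrast rests on a limit, not a number: the limit of > 100000 nM in this assay, at which 1 of the 3 values shown sits.

Going by these compounds, the true size of the gap at compound 1 stays open. So does whether a longer chain, or a carboxylic acid in place of the hydroxycarbamoyl end, would move the number beyond the scatter.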